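Fluorine-to-methyl swap on a cyclopropyl amide

A few compounds are considered here, and "the series" means these few. Any claim that something is new, unique, unknown or untested is made for them only; others in the source may bear on it.

Measured so far:
- compound 1, `O=C([C@@H]1C[C@@H]1F)N1CC2CC(C1)N2`: 120 nM
- compound 2, `O=C([C@H]1C[C@@H]1F)N1CC2CC(C1)N2`: 850 nM

Both compounds were tested in an assay on SH-EP1 cells for agonist activity at Neuronal acetylcholine receptor; alpha4/beta2 (Homo sapiens), read by FLIPR and calcium flux; a lower number here means that less compound is needed, a higher number that more compound is needed for the effect. Compound 2 gives the highest of the two numbers shown; its only neighbour is compound 1, and the step of a 7.1-fold higher number from compound 1 to compound 2 (0.85 log units; beyond the scatter) separates them. The two share every atom and bond and differ only in how one ring carbon is drawn, a point noted as the fact that one of compounds 1 and 2 is drawn with a defined configuration and the other without, at the place where they differ.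

Compound 3, `C[C@H]1C[C@H]1C(=O)N1CC2CC(C1)N2`, has not been measured. Its change from compound 2 is 2-methylcyclopropyl in place of 2-fluorocyclopropyl on a carbonyl carbon: a 2-methylcyclopropyl in place of a 2-fluorocyclopropyl on the carbonyl carbon, the fluorine leaving and a carbon entering, with the ring and both defined stereocentres retained.

Among the compounds with values here, no measured step swaps fluorine for methyl; the single step known, a 7.1-fold higher number from compound 1 to compound 2 (0.85 log units; beyond the scatter), concerns drawing of a stereocentre and does not speak to this exchange. The expectation for compound 3 is therefore a number near that of compound 2, with the step of no change at the digits printed from compound 2 to compound 3 (within the scatter) expected to stay within the scatter. The estimate for compound 3 is 850 nM, ranging from 250 nM to 3000 nM.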

Compound 3, half-maximal effective concentration: 2200 nM
The estimate for compound 3 lay 2.6-fold (0.41 log units) below the measured number, within the range that was stated.
By their numbers in this assay, from the lowest: compound 1; then compound 2; then compound 3.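

In this assay the group on the carbonyl carbon turns out to matter for more than its drawn configuration: methyl in place of fluorine gives a 2.6-fold higher number from compound 2 to compound 3 (0.41 log units; beyond the scatter) and, measured against the other fluorinated compound, an 18-fold higher number from compound 1 to compound 3 (1.26 log units; beyond the scatter). Before this result, the only change seen was at a single stereocentre, whereas here the atom carried on the saturated ring carbon changes and the number rises in both listed steps, each beyond the usual scatter. The one available note concerns how a stereocentre is drawn, so it gives no reason for the rise seen with this exchange.

The compounds shown leave open how other groups on that ring carbon would compare, such as a hydroxyl, a chlorine atom or an ethyl chain, and whether a plain cyclopropyl with no added group would sit nearer the fluorinated compounds or nearer the methyl one. They also leave open how a methyl compound with the other arrangement at the changed stereocentre would compare with compound 3.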